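From 1,3-benzothiazol-5-yl to 1,3-benzoxazol-5-yl

The compounds below may be only part of what the source reports. "The series", "measured", "known", "first", "only" and "open" are said of these compounds alone.

Compound 1 `CC/C(=C(/c1ccc(/C=C/C(=O)O)cc1)c1ccn2nccc2c1)c1ccccc1`: > 500 nM (a limit of the assay, not a number)
Compound 2 `CC/C(=C(/c1ccc(/C=C/C(=O)O)cc1)c1ccc2scnc2c1)c1ccccc1`: 90 nM

Both results come from a functional assay on MCF7 cells (Homo sapiens) for antiproliferative activity, read by CellTiter-Glo, with a stated time of 5 days; on this read-out lower numbers stand for stronger inhibition and higher numbers for weaker inhibition. Among the measured compounds shown here, compound 2 holds the only true number so far. The result for compound 1 is only a limit.

Compound 3 `CC/C(=C(/c1ccc(/C=C/C(=O)O)cc1)c1ccc2ocnc2c1)c1ccccc1` keeps the core of compound 2 and changes one group: 1,3-benzoxazol-5-yl in place of 1,3-benzothiazol-5-yl on a double-bonded chain carbon bound to an aromatic carbon and a double-bonded chain carbon. For the measured compounds named here, the one measured step, an at least 5.5-fold lower number from compound 1 to compound 2 (0.74 log units; beyond the scatter), exchanged a different group at the same place, so a change here can move the read-out. That step does not test oxygen against sulfur, however. Compound 2 gives 90 nM, and the entering group has the same ring types and the same donor and acceptor counts, so only a small change is expected, with no firm direction. The expected step is a 1.3-fold higher number from compound 2 to compound 3 (0.12 log units; within the scatter), estimated to stay within the scatter. For compound 3 the estimated value is 120 nM, with an expected range from 40 nM to 400 nM.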

Compound 3, half-maximal inhibitory concentration: > 500 nM
Compound 3: only a limit was reported (the forecaster's own chance of this, stated with the estimate: 12%); middle value at least 4.1-fold (0.61 log units) away from the limit.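

Exchanging the sulfur of 1,3-benzothiazol-5-yl for the oxygen of 1,3-benzoxazol-5-yl gives an at least 5.5-fold higher number from compound 2 to compound 3 (0.74 log units; beyond the scatter), so at this place the read-out separates two groups with the same ring types and the same donor and acceptor counts. Among the compounds shown here, the one earlier readable step exchanged a group with different ring types, so it could not show that a single ring atom can matter here. The result for compound 3 is a limit, and the step between compound 1 and compound 3 cannot be read: the limit of > 500 nM in this assay, at which 2 of the 3 values shown sit.

For the compounds shown here, compound 2 is still the only compound with a true number, so it remains open how much weaker compound 3 really is. Also open, as far as these compounds go, is whether a 1,3-benzothiazol-5-yl group carrying an added methyl or amine would keep the activity of compound 2.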